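From a saturated chain to a diene chain

This account rests on a few compounds, and the source may have more. Where it says the series, first, only, none or still open, it means among the compounds named here.

Measured so far in a functional assay on MCF7 cells (Homo sapiens) for antiproliferative activity, read by MTT assay (on this read-out higher numbers stand for weaker inhibition and lower numbers for stronger inhibition), for two compounds:
Compound 1 (`CCCCC/C=C\C/C=C\CCCCCCCc1cc(=O)c2c(O)c(C)c(OCOC)c(C)c2o1`) gives > 84100 nM as a limit
Compound 2 (`CCCCCCCCCCCCCCCc1cc(=O)c2c(O)c(C)c(O)c(C)c2o1`) gives > 67200 nM as a limit

Within the data shown here, compound 2 thus stands at a limit (> 67200 nM) and has no number in this assay so far. Compound 3 (`CCCCC/C=C\C/C=C\CCCCCCCc1cc(=O)c2c(O)c(C)c(O)c(C)c2o1`) keeps the core of compound 2 and differs in its chain (deca-1,4-dien-1-yl in place of octyl on a saturated chain carbon, seven bonds along the chain from an aromatic carbon) only. Among the measured compounds shown here, no measured step shows what such a change does, so in this assay no step beyond the scatter is expected. The estimated step (a step that the limit leaves unreadable from compound 2 to compound 3) stays within that expectation. Compound 3 is expected at 70000 nM with an estimated range from 25000 nM to 120000 nM and may also read as a limit.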

Compound 3, half-maximal inhibitory concentration: > 84100 nM
Compound 3 was reported as a limit; the forecaster's own chance of this, stated with the estimate: 70%; middle value at least 1.2-fold (0.07 log units) from the limit.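

Compound 3 gives > 84100 nM, which is a limit. Among these compounds, compound 1 and compound 2 also stand at limits, so no step from either to compound 3 can be read. The compounds shown leave open what deca-1,4-dien-1-yl in place of octyl, or hydrogen in place of methoxymethyl, does in this assay.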